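The source may report more compounds than this note shows. Statements on the series, on what has been measured and on what is new or still open speak of the compounds shown alone.

Compound 1, `Cn1c(=O)c(S(=O)(=O)Cc2ccc(F)cc2)cc2cnc(Nc3ccc4[nH]ccc4c3)nc21`: 30000 nM
Compound 2, `Cc1ccc(S(=O)(=O)c2cc3cnc(Nc4cccc5cccnc45)nc3n(C)c2=O)cc1`: 10000 nM

In a functional assay on K562 cells (Homo sapiens) for inhibition, read by trypan blue exclusion, with a stated time of 72 h (on this read-out lower numbers stand for stronger inhibition and higher numbers for weaker inhibition), compound 1 gives 30000 nM, and compound 2 gives 10000 nM. Compound 2 thus has the lower of the two numbers, and its gap to compound 1 lies beyond the scatter of the assay, though no single-point comparison between these two compounds exists, as they differ in more than one place.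

Compound 3, `Cc1ccc(S(=O)(=O)c2cc3cnc(Nc4cnc5c(c4)CC(=O)N5)nc3n(C)c2=O)cc1`, has not yet been measured in this assay. It differs from compound 2 in one place: a group of 10 heavy atoms (7 carbon, 2 nitrogen, 1 oxygen; one five-membered non-aromatic ring with 1 hetero atom, one six-membered aromatic ring with 1 hetero atom) in place of a group of 10 heavy atoms (9 carbon, 1 nitrogen; one six-membered aromatic ring of carbon only, one six-membered aromatic ring with 1 hetero atom), on a nitrogen on an aromatic ring. The change keeps the size of the group but brings in a hydrogen-bond donor and an extra acceptor, and removes the carbon-only ring. Among the measured compounds shown here, with no measured step of this kind to draw on, the direction is uncertain; a small gain is expected, but the estimate carries a wide range. The step from compound 2 to compound 3 is expected to be a 2.0-fold lower number from compound 2 to compound 3 (0.30 log units; within the scatter). Compound 3 is expected to give 5000 nM, between 1000 nM and 30000 nM.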

Compound 3, half-maximal inhibitory concentration: 15000 nM
For compound 3 the middle estimate is 3.0-fold (0.48 log units) below the measured one; low and high end bracket the measured number.
By their numbers in this assay, from the lowest: compounds 2, 3 and 1 (each within the scatter of the next, the first and the last beyond it).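

In this assay, replacing quinolin-8-yl with the group holding a five-membered non-aromatic ring, on a nitrogen on an aromatic ring, gives a 1.5-fold higher number from compound 2 to compound 3 (0.18 log units; within the scatter). Among the compounds shown here, this is the first one-place comparison: at this position, a carbon-only ring can give way to a group with the same count of 10 heavy atoms, with a carbonyl and a hydrogen-bond donor, without moving the number beyond the scatter. No measurement shown here offers an explanation for this result.

What the compounds leave open is whether a group of another kind on this nitrogen, such as a phenyl ring carrying a piperazine, would separate clearly from compound 2. Also open, on these data alone, is how the group on the sulfonyl contributes on its own, since compound 1 differs from compound 2 in more than one place.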